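Amino Substitution on a Chloropurine Core and Cell Tolerance

This account rests on a few compounds, and the source may have more. Where it says the series, first, only, none or still open, it means among the compounds named here.

Compound 1 `ClCc1ccc(Cn2cnc3c(Cl)ncnc32)cc1` was tested in a functional assay on NCI-H322M cells (Homo sapiens) for cytotoxicity, read by sulforhodamine B assay, with a stated time of 48 h (a lower number here means that less compound is tolerated, a higher number that more compound is tolerated), where compound 1 gives 9330 nM. Compound 2 `Nc1nc(Cl)c2ncn(Cc3ccc(CCl)cc3)c2n1` differs from it by one change (amino in place of hydrogen on an aromatic carbon), and in this assay compound 2 gives 87100 nM, a step of a 9.3-fold higher number from compound 1 to compound 2 (0.97 log units; beyond the scatter). Compound 3 `ClCc1ccccc1Cn1cnc2c(Cl)ncnc21` carries the same atoms as compound 1 joined differently; the difference between the two cores is not broken down here. In this assay compound 3 gives 43700 nM. Compound 4 `Nc1nc(Cl)c2ncn(Cc3ccccc3CCl)c2n1` has not yet been measured; it differs from compound 3 by amino in place of hydrogen on an aromatic carbon, the same change seen from compound 1 to compound 2. Because of a 9.3-fold higher number from compound 1 to compound 2 (0.97 log units; beyond the scatter), a step of similar size is expected, namely a 6.9-fold higher number from compound 3 to compound 4 (0.84 log units; beyond the scatter). Compound 4 is therefore estimated to give 300000 nM, with a likely span from 80000 nM to 1000000 nM.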

Compound 4, concentration lethal to 50% of the cells: 69200 nM
Compound 4: middle estimate off by 4.3-fold (0.64 log units), on the high side; measured number outside the range, below it.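

In this assay, putting an amino group in place of hydrogen gives a 1.6-fold higher number from compound 3 to compound 4 (0.20 log units; within the scatter), so the large step seen on the core of compound 1 does not carry over to the core of compound 3. The two steps do not match: the same change on two cores in this assay, a 9.3-fold higher number (0.97 log units; beyond the scatter) from compound 1 to compound 2 and a 1.6-fold higher number (0.20 log units; within the scatter) from compound 3 to compound 4, 5.9-fold (0.77 log units) apart, beyond the scatter of two such steps. This shows that, in these two pairs, the size of the step differs between the cores, but it does not show what in the cores sets that difference or how the change would behave on a further core.

The compounds shown leave open whether a different group on that same aromatic carbon, such as a methylamino or a hydroxyl group, would give a step that matches across both cores.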